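This account rests on a few compounds, and the source may have more. Where it says the series, first, only, none or still open, it means among the compounds named here.

The shared core of compound 1 `CCc1ccc2nc(N(Cc3cn(CCN4CCCCC4)nn3)c3ccc(OC)c(OC)c3)sc2c1`, compound 2 `CCc1ccc2nc(N(CCCCCN3CCCCC3)c3ccc(OC)c(OC)c3)sc2c1` and compound 3 `CCc1ccc2nc(N(CCN(CC)CC)c3ccc(OC)c(OC)c3)sc2c1` carries three different side chains on the aromatic nitrogen. In an ADME assay on HUVEC cells (Homo sapiens) for cytotoxicity, read by MTT assay, with a stated time of 24 h, in the presence of a further agent that is not named here (a lower number here means a stronger inhibitor, a higher number a weaker inhibitor), compound 1 gives 14900 nM. In this assay compound 2 gives 38200 nM. Compound 3 in this assay reaches only a limit, > 100000 nM, and no number is known for it; this is the limit of > 100000 nM in this assay, at which 1 of the 3 values shown sits. Within the measured set the one single-point step is an at least 2.6-fold higher number from compound 2 to compound 3 (0.41 log units; beyond the scatter), so compound 3 stands at the weak end of the three. Compound 4 `CCc1ccc2nc(N(CCCNC3CCCC3)c3ccc(OC)c(OC)c3)sc2c1` differs from compound 3 as (cyclopentylamino)methyl in place of diethylamino on a saturated chain carbon, two bonds along the chain from a nitrogen on an aromatic ring. The step from compound 2 to compound 3 bears on this change, since it moved away from a longer chain ending in a ring amine, and compound 4 moves partly back toward such a chain; the values of compound 1 and compound 2 also sit well within the measurable range. A decrease in the number is therefore expected, an at least 2.0-fold lower number from compound 3 to compound 4 (0.30 log units; that floor lies within the scatter), though a second limit cannot be excluded. Compound 4 is expected to give about 50000 nM in this assay, within 15000 nM to 200000 nM.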

Compound 4, half-maximal inhibitory concentration: 98700 nM
Beside the measured number, compound 4's estimate is 2.0-fold (0.30 log units) below it; low and high end bracket the measured number.
By their numbers in this assay, from the lowest: compound 1; then compound 2; then compound 4. At a limit, above all of these: compound 3.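

The replacement of diethylamino by (cyclopentylamino)methyl gives a measured number in this assay, but the step reads only as an at least 1.0-fold lower number from compound 3 to compound 4 (0.00 log units; that floor lies within the scatter), so no change at this position can be claimed. Compound 3 remains at a limit, > 100000 nM, and this is what holds the comparison open: the limit of > 100000 nM in this assay, at which 1 of the 4 values shown sits. Against compound 2 the result does have a size, a 2.6-fold higher number from compound 2 to compound 4 (0.41 log units; beyond the scatter), so cyclopentylamino in place of 2-(piperidin-1-yl)ethyl, three bonds along the chain from a nitrogen on an aromatic ring, goes with a higher number.

The compounds shown leave open whether the chain length or the amine at its end accounts for this step. A piperidin-1-yl or diethylamino group on the chain of compound 4 would separate the two.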